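This account rests on a few compounds, and the source may have more. Where it says the series, first, only, none or still open, it means among the compounds named here.

In a functional assay on HCT-116 cells (Homo sapiens) for antiproliferative activity, read by MTT assay, with a stated time of 72 h (a higher number here means a weaker inhibitor, a lower number a stronger inhibitor), compound 1 `C/C=C1/[C@H](O[C@@H]2O[C@H](CO)[C@@H](O)[C@H](O)[C@H]2O)OC=C(C(=O)OC)[C@H]1CC(=O)OCCC1CCCCC1` gives 13700 nM, and compound 2 `C/C=C1/[C@H](O[C@@H]2O[C@H](COC(C)=O)[C@@H](OC(C)=O)[C@H](OC(C)=O)[C@H]2OC(C)=O)OC=C(C(=O)OC)[C@H]1CC(=O)OCCC` gives 25700 nM. Going by the values given here, these two numbers lie within the usual scatter of each other, so compound 1 stands level with the only other measured compound. Among the compounds with values here, the two structures differ in more than one place, so this pair offers no clean single-change step to learn from. Compound 3 `C/C=C1/[C@H](O[C@@H]2O[C@H](CO)[C@@H](O)[C@H](O)[C@H]2O)OC=C(C(=O)OC)[C@H]1CC(=O)OCCc1ccccc1` keeps the core of compound 1 but has phenyl in place of cyclohexyl on a saturated chain carbon, two bonds along the chain from an oxygen next to a carbonyl group. Within the data shown here, with no measured step as a guide, no change beyond the scatter is expected in this assay. Compound 3 is estimated at 15000 nM, with an expected range from 5000 nM to 40000 nM. Expressed as a step, the estimate is a 1.1-fold higher number from compound 1 to compound 3 (0.04 log units; within the scatter).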

Compound 3, half-maximal inhibitory concentration: 25300 nM
Estimate against measurement, compound 3: 1.7-fold (0.23 log units) below, within the range that was stated.
By their numbers in this assay, from the lowest: compounds 1, 3 and 2 (each within the scatter of the next).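

In this assay, putting phenyl in place of cyclohexyl on a saturated chain carbon, two bonds along the chain from an oxygen next to a carbonyl group, gives a 1.8-fold higher number from compound 1 to compound 3 (0.27 log units; within the scatter). Going by these compounds alone, this is the first single-change comparison in the set, and it shows that the assay does not tell these two rings apart at this position, even though one is aromatic and the other is not. No measurement at hand explains this result.

Going by these compounds, both rings here are bare carbon rings, so it remains open what a phenyl carrying an amine or a carboxylic acid would give, or a longer chain leading to the ring. Compound 2 differs from compound 1 in more than one place, so the contribution of each of those differences also remains unresolved.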